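Replacing the amide-linked aryl with a direct aryl

The source may report more compounds than this note shows. Statements on the series, on what has been measured and on what is new or still open speak of the compounds shown alone.

compound 1: `CCOC(=O)C1=Cc2ccccc2OC1(OCc1cn(-c2ccc(F)cc2)nn1)C(F)(F)F`, 8900 nM
compound 2: `CCOC(=O)C1=Cc2ccccc2OC1(OCc1cn(CC(=O)Nc2ccccc2Br)nn1)C(F)(F)F`, a limit of the assay, > 150000 nM
compound 3: `CCOC(=O)C1=Cc2ccccc2OC1(OCc1cn(CC(=O)Nc2ccccc2F)nn1)C(F)(F)F`, 33900 nM

Going by the values given here, in a functional assay on DU-145 cells (Homo sapiens) for inhibition, read by MTT assay, with a stated time of 24 h (a higher number here means a weaker inhibitor, a lower number a stronger inhibitor), compound 3 gives 33900 nM, the highest of the two numbers known here; the step of a 3.8-fold higher number from compound 1 to compound 3 (0.58 log units; beyond the scatter) shows where the only other number stands. Compound 2 reaches only a limit of the assay, > 150000 nM; this is the limit of > 150000 nM in this assay, at which 1 of the 3 values shown sits.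

Compound 4, `CCOC(=O)C1=Cc2ccccc2OC1(OCc1cn(-c2ccc(F)c(Cl)c2)nn1)C(F)(F)F`, differs from compound 3 in one place: 3-chloro-4-fluorophenyl in place of ((2-fluorophenyl)carbamoyl)methyl on an aromatic nitrogen. The measured step that bears on this change is the one from the directly attached aryl to the amide-linked aryl, a 3.8-fold higher number from compound 1 to compound 3 (0.58 log units; beyond the scatter), a modest rise in the number. Among the compounds with values here, compound 4 reverses that change and carries an extra chloro on the ring, for which no measured step exists. The step of an at least 4.4-fold lower number from compound 2 to compound 3 (0.64 log units; beyond the scatter) concerns a halogen swap on the amide-linked ring and bears only loosely here. A modest fall in the number is therefore expected, a 4.2-fold lower number from compound 3 to compound 4 (0.63 log units; beyond the scatter). Compound 4 is estimated at 8000 nM, within 2500 nM to 30000 nM.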

Compound 4, half-maximal inhibitory concentration: 21500 nM
Compound 4: middle estimate off by 2.7-fold (0.43 log units), on the low side; the measured number falls inside the stated range.
By their numbers in this assay, from the lowest: compound 1; then compounds 4 and 3 (each within the scatter of the next). At a limit, above all of these: compound 2.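

In this assay, the added chloro on the directly attached aryl ring does not leave the number unchanged: a 2.4-fold higher number from compound 1 to compound 4 (0.38 log units; beyond the scatter), a modest step beyond the scatter. The gain seen with the directly attached 4-fluorophenyl therefore does not carry over to every direct aryl, since a 1.6-fold lower number from compound 3 to compound 4 (0.20 log units; within the scatter), within the scatter, leaves 3-chloro-4-fluorophenyl and ((2-fluorophenyl)carbamoyl)methyl on the aromatic nitrogen indistinguishable here, and compound 4 goes against any rule that direct aryl beats amide-linked aryl. The comparison with compound 2 gives only a bound, an at least 6.9-fold lower number from compound 2 to compound 4 (0.84 log units; beyond the scatter), because compound 2 stands at a limit: the limit of > 150000 nM in this assay, at which 1 of the 4 values shown sits.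

The compounds shown leave open how a methoxy group or an amine in place of the chloro would read. They also leave open how a longer chain on the aromatic nitrogen would read.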